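The source may hold more compounds than are shown below. What is called first, only, known or untested is meant among the compounds shown, and "the series" means these compounds.

Measured compounds:
compound 1 `Cc1cc(O)c(C(=O)/C=C/c2ccccc2)c(-c2ccccc2)c1C(=O)/C=C/c1ccccc1`: 8500 nM
compound 2 `Cc1cc(O)c(C(=O)/C=C/c2ccccc2)c(-c2ccc(Br)cc2)c1C(=O)/C=C/c1ccccc1`: 8000 nM

Both numbers come from a functional assay on MDA-MB-231 cells (Homo sapiens) for cytotoxicity, read by MTT assay, with a stated time of 24 h; a higher number here means a weaker inhibitor, a lower number a stronger inhibitor. Among the measured compounds shown here, compound 2 has the lower of the two values, but the only step that joins them, a 1.1-fold lower number from compound 1 to compound 2 (0.03 log units; within the scatter), lies within the scatter, so the two compounds cannot be told apart on these data.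

Compound 3 `Cc1cc(O)c(C(=O)/C=C/c2ccccc2)c(-c2ccc(OCc3ccccc3)cc2)c1C(=O)/C=C/c1ccccc1` is not yet measured. It differs from compound 2 in one place: benzyloxy in place of bromo on an aromatic carbon. For the measured compounds named here, the only measured step that touches this position is the one from compound 1 to compound 2, where bromo replaced hydrogen, and that step was within the scatter. Going by the values given here, no measured pair shows what a benzyloxy group does anywhere on the shared core, so the expectation rests on the single step at this position, which changed nothing beyond the scatter.

Compound 3 is therefore expected to stay close to compound 2, with no change at the digits printed from compound 2 to compound 3 (within the scatter) as the estimated step. The expected value for compound 3 in this assay is 8000 nM, with a range from 3500 nM to 18000 nM.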

Compound 3, half-maximal inhibitory concentration: "not active" (no number reported)
The entry for compound 3 holds no number; no gap can be computed for the estimate.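

Among the compounds shown here, compound 3 is reported as "not active" in this assay, with no number, so no step from compound 2 to compound 3 can be read. Nothing shown offers an explanation for this entry. From the compounds shown here alone, what remains open is how far benzyloxy in place of bromo separates compound 3 from compound 2 on a numerical scale.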